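The source may hold more compounds than are shown below. What is called first, only, known or untested is meant among the compounds shown, and "the series" means these compounds.

Three compounds share one core and differ only at a single aromatic carbon. Compound 1 `N#Cc1ccc2c(c1)S(=O)(=O)C=C(c1c(O)c3cc(F)ccc3n(Cc3ccc(F)cc3)c1=O)N2` carries a cyano group there, compound 2 `Nc1ccc2c(c1)S(=O)(=O)C=C(c1c(O)c3cc(F)ccc3n(Cc3ccc(F)cc3)c1=O)N2` an amino group, and compound 3 `CS(=O)(=O)Nc1ccc2c(c1)S(=O)(=O)C=C(c1c(O)c3cc(F)ccc3n(Cc3ccc(F)cc3)c1=O)N2` a methanesulfonamido group. In an ADME assay on 2209-23 cells (Homo sapiens) for cytotoxicity, read by WST assay (on this read-out higher numbers stand for lower toxicity in this test and lower numbers for higher toxicity in this test), compound 1 gives > 50000 nM, which is a limit of the assay rather than a number. In this assay compound 2 gives > 50000 nM, again only a limit. In this assay compound 3 gives > 50000 nM, also a limit. Going by the values given here, compound 3 thus stands where every value so far stands: the limit of > 50000 nM in this assay, at which 3 of the 3 values shown sit. The steps among the measured compounds, a step that the two limits leave unreadable from compound 1 to compound 2, a step that the two limits leave unreadable from compound 1 to compound 3 and a step that the two limits leave unreadable from compound 2 to compound 3, are all unreadable in size.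

Compound 4 `Cc1cc(Cn2c(=O)c(C3=CS(=O)(=O)c4cc(NS(C)(=O)=O)ccc4N3)c(O)c3cc(F)ccc32)ccc1F` departs from compound 3 in another part of the molecule: methyl in place of hydrogen on an aromatic carbon. Among the compounds with values here, none of the measured steps touches the 4-fluorobenzyl group, so none bears directly on this change; they show only that each variation examined so far has left the value at the limit. This step is expected to be a step that the limit leaves unreadable from compound 3 to compound 4, no move beyond the scatter. Compound 4 is therefore expected to give about 70000 nM in this assay, with a range from 30000 nM to 200000 nM, most probably reported once more only as a limit.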

Compound 4, half-maximal cytotoxic concentration: > 50000 nM
Compound 4 gave a limit, no number (the forecaster's own chance of this, stated with the estimate: 85%); the middle value is on the limit's open side.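

Compound 3 and compound 4 both stand at a limit in this assay, so no size can be read for the change from hydrogen to methyl. The compounds shown leave open how far each lies from that limit, and whether any of these changes shifts the value at all: the limit of > 50000 nM in this assay, at which 4 of the 4 values shown sit.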